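Quaternary ammonium in place of the tertiary amine

The source may report more compounds than this note shows. Statements on the series, on what has been measured and on what is new or still open speak of the compounds shown alone.

Measured so far in an in vitro functional assay on HEK ts201 cells for antagonist activity at Neuronal acetylcholine receptor; alpha4/beta2 (Homo sapiens), read by fluorescence and calcium flux; on this read-out lower numbers stand for stronger inhibition and higher numbers for weaker inhibition:
compound 1 `O=C(OCC1CCCNC1)c1ccccc1-c1ccccc1`: 7080 nM
compound 2 `CN1CCCC(COC(=O)c2ccccc2-c2ccccc2)C1`: 6920 nM
compound 3 `O=C(OCC1CCCN(C(=O)CCc2ccccc2)C1)c1ccccc1-c1ccccc1`: 5600 nM; 6030 nM (2 entries)

On the step of a 1.0-fold lower number from compound 1 to compound 2 (0.01 log units; within the scatter) the number barely moves; compound 2 therefore stands at the same level as compound 1 within the scatter, and the repeated entries of compound 3 the several entries of compound 3 in this assay, 5600 nM; 6030 nM (2 entries) lie close to both. Compound 4 `C[N+]1(C)CCCC(COC(=O)c2ccccc2-c2ccccc2)C1` carries a group of 8 heavy atoms (7 carbon, 1 nitrogen; one six-membered non-aromatic ring with 1 hetero atom) in place of a group of 7 heavy atoms (6 carbon, 1 nitrogen; one six-membered non-aromatic ring with 1 hetero atom), on a saturated chain carbon bound to an oxygen next to a carbonyl group. For the measured compounds named here, the only measured step in this assay, a 1.0-fold lower number from compound 1 to compound 2 (0.01 log units; within the scatter), altered the same ring nitrogen and stayed within the scatter; no measured step introduces a net charge, so the expectation rests on weak ground. The expected step is a 1.1-fold higher number from compound 2 to compound 4 (0.03 log units; within the scatter), that is none beyond the scatter, with wide uncertainty. Compound 4 is estimated at 7500 nM with a range of 2500 nM to 25000 nM in this assay.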

Compound 4, half-maximal inhibitory concentration: 2400 nM
For compound 4 the middle estimate is 3.1-fold (0.49 log units) above the measured one; measured number below the stated range.
By their numbers in this assay, from the lowest: compound 4; then compounds 2 and 1 (each within the scatter of the next).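

For the compounds shown here, at this position, on a saturated chain carbon bound to an oxygen next to a carbonyl group, the entering group with net charge +1 produces the first steps beyond the scatter in this assay: a 2.9-fold lower number from compound 2 to compound 4 (0.46 log units; beyond the scatter) and a 3.0-fold lower number from compound 1 to compound 4 (0.47 log units; beyond the scatter). Changing the ring nitrogen can therefore move the number, though the steps are modest. Nothing measured here accounts for these steps.

Still open, as far as these compounds go, is whether the shift follows the net charge itself or the particular substituents on the nitrogen. Ethyl or benzyl groups on the quaternary nitrogen would test this.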